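One Change at the Far End of Compound 3

The compounds below may be only part of what the source reports. "The series", "measured", "known", "first", "only" and "open" are said of these compounds alone.

Of the compounds shown here, three sharing one core have been measured in an assay on isolated protein for inhibition of Rho-associated protein kinase 1 (Homo sapiens), read by scintillation counting, radiometric assay and 33P incorporation, with a stated time of 40 min, in the presence of a further agent that is not named here; on this read-out lower numbers stand for stronger inhibition and higher numbers for weaker inhibition. Compound 1 `CN(C)c1ccc(C(=O)Nc2cccc(NC(=O)COc3ccc4c(c3)NC(=O)CC4)c2)cc1` gives > 10000 nM in this assay, which is a limit of the measurement rather than a number. That value sits at the limit of > 10000 nM in this assay, at which 1 of the 3 values shown sits. Compound 2 `COc1cc(OCC(=O)Nc2cccc(NC(=O)c3ccc(N(C)C)cc3)c2)ccc1C=O` gives 3740 nM in this assay. Among the compounds with values here, the single change between these two, on an oxygen on a saturated carbon, brings an at least 2.6-fold lower number from compound 1 to compound 2 (0.42 log units; beyond the scatter). Compound 3 `Cc1ccc(C(=O)Nc2cccc(NC(=O)COc3ccc4c(=O)ccoc4c3)c2)cc1` gives 183 nM in this assay, the lowest of the two numbers, far below the value of compound 2 by a gap that lies beyond the usual scatter.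

Compound 4 `COC(=O)c1ccc(C(=O)Nc2cccc(NC(=O)COc3ccc4c(=O)ccoc4c3)c2)cc1` differs from compound 3 at one place only: methoxycarbonyl in place of methyl on an aromatic carbon. Within the data shown here, no measured step touches this part of the molecule; the one step that has been measured lies on the oxygen side of the core, so it offers no guide to the size or direction of this change. Without any precedent, the expectation is a step that stays within the scatter, so compound 4 is expected to give about 250 nM in this assay, within a range from 80 nM to 800 nM. The step this estimate implies, a 1.4-fold higher number from compound 3 to compound 4 (0.14 log units; within the scatter), is expected to remain inside the usual scatter.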

Compound 4, half-maximal inhibitory concentration: 72 nM
The estimate for compound 4 lay 3.5-fold (0.54 log units) above the measured number; measured number below the stated range.
By their numbers in this assay, from the lowest: compound 4; then compound 3; then compound 2. At a limit, above all of these: compound 1.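

Within the data shown here, this is the first measured change at this end of the molecule, on an aromatic carbon para to a large group, and in this assay it shows that the position is not indifferent to what sits there: a 2.5-fold lower number from compound 3 to compound 4 (0.41 log units; beyond the scatter). The step also shows that a larger group can take the place of the small one here without a loss, since methoxycarbonyl, with 2 hydrogen-bond acceptors, replaces methyl, with no such acceptors, and the number goes down rather than up. Nothing in the data shown identifies which feature of the new group accounts for this step.

This is still a single pair, so a carboxylic acid, an ethoxycarbonyl group or a simple amide at the same place would be needed to tell whether the step follows the carbonyl, the ester oxygen or the methyl at its end. Among these compounds, it also remains open whether methoxycarbonyl gives a similar step when the group on the other side of the shared core is the one carried by compound 2.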